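Carbonyl substituent variation in a small furan-bearing series

The source may report more compounds than this note shows. Statements on the series, on what has been measured and on what is new or still open speak of the compounds shown alone.

Measured so far, all in an assay on membranes from HeLa cells for displacement of a labelled ligand from adenosine receptor A3 (Homo sapiens), read by scintillation counting, with a stated time of 180 min, tested at 1 uM; a lower number here means less inhibition, a higher number more inhibition at the concentration tested (going by the name of the read-out):

compound 1 , `CC1=C(C(=O)OCc2ccccc2)C(c2ccco2)NC(=O)N1`: 3%
compound 2 , `CC1=C(C(=O)NC(C)C)C(c2ccco2)NC(=O)N1`: 4%
compound 3 , `CCSC(=O)C1=C(C)NC(=O)NC1c1ccco1`: 14%

Compound 3 holds the highest of the three numbers in this assay. Its nearest neighbour is compound 2, and the step of a number 10 percentage points higher from compound 2 to compound 3 (within the scatter) lies within the usual scatter. Its furthest neighbour is compound 1, whose number is lower by a gap that lies beyond the scatter.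

The next compound is compound 4, `CC1=C(C(=O)OCC2CCC2)C(c2ccco2)NC(=O)N1`. The change from compound 3 is cyclobutylmethoxy in place of ethylsulfanyl on a carbonyl carbon. Among the measured compounds shown here, only one measured step bears on it, a number 10 percentage points higher from compound 2 to compound 3 (within the scatter), and that step is small and concerns an amino-to-sulfanyl exchange, not a sulfanyl-to-alkoxy one. For the measured compounds named here, the one alkoxy compound measured, compound 1, gives the lowest value in this assay, 3%. A move back toward that level is therefore expected for compound 4, a step of a number 8 percentage points lower from compound 3 to compound 4 (within the scatter), which would itself fall within the scatter. Compound 4 is estimated at 6%, with a range from 0% to 20%.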

Compound 4, a percentage reported as inhibition, at one concentration (the size of the read-out at that concentration, not a potency): 1%
Compound 4: the middle estimate sits 5 percentage points above what was measured; low and high end bracket the measured number.
By their numbers in this assay, from the lowest: compounds 4, 1, 2 and 3 (each within the scatter of the next, the first and the last beyond it).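

In this assay, among the compounds shown here, cyclobutylmethoxy in place of ethylsulfanyl on the carbonyl carbon gives a number 13 percentage points lower from compound 3 to compound 4 (beyond the scatter), the first step between compounds differing in one place that is printed as beyond the scatter. The other two steps, a number 3 percentage points lower from compound 2 to compound 4 (within the scatter) and a number 2 percentage points lower from compound 1 to compound 4 (within the scatter), stay within the scatter, so neither cyclobutylmethoxy against isopropylamino nor cyclobutyl against phenyl on the ester chain separates these compounds. No measurement shown bears on the reason for the step away from ethylsulfanyl.

Going by these compounds, whether the sulfanyl link or the ethyl group goes with the number of compound 3 stays open, and a longer chain such as propylsulfanyl or a small ester such as ethoxy would test this. A free carboxylic acid at the same carbonyl carbon is also an open case.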